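A few compounds are considered here, and "the series" means these few. Any claim that something is new, unique, unknown or untested is made for them only; others in the source may bear on it.

Compound 1 `Cn1c(-c2ccc([N+](=O)[O-])cc2)nc2cc(C(F)(F)F)ccc21`: in an ADME assay on Vero cells (Chlorocebus sabaeus) for cytotoxicity (a higher number here means that more compound is tolerated, a lower number that less compound is tolerated), compound 1 gives > 100000 nM, which is a limit of the assay.
Compound 2 `CC(=O)Nc1ccc(-c2nc3cc([N+](=O)[O-])ccc3[nH]2)cc1`: in this assay compound 2 gives > 100000 nM, again a limit.
Compound 3 `O=[N+]([O-])c1ccc(-c2nc3cc(C(F)(F)F)ccc3n2C2CCCCC2)cc1`: in this assay compound 3 gives > 100000 nM, also a limit.

Compound 3 therefore stands at the same limit as every other value shown; nothing places it higher or lower (the limit of > 100000 nM in this assay, at which 3 of the 3 values shown sit). Compound 4 `Nc1ccc(-c2nc3cc(C(F)(F)F)ccc3n2C2CCCCC2)cc1` differs from compound 3 as follows: amino in place of nitro on an aromatic carbon. Going by the values given here, only one step between measured compounds exists, a step that the two limits leave unreadable from compound 1 to compound 3, and it changes a different place, so no measured step bears on this change. With all three values sitting at the limit, the step expected from compound 3 to compound 4 is a number no higher from compound 3 to compound 4 (the limit leaves the size open), none beyond the scatter. Compound 4 is estimated at 100000 nM, ranging from 30000 nM to 300000 nM.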

Compound 4, half-maximal cytotoxic concentration: > 100000 nM
Compound 4 ended at the assay's limit; the forecaster's own chance of this, stated with the estimate: 70%; the middle value sits exactly at the limit.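

Compound 3 and compound 4 both sit at the limit of this assay, so no step can be read for amino in place of nitro. How much of any compound shown is tolerated stays open, since all share one ceiling: the limit of > 100000 nM in this assay, at which 4 of the 4 values shown sit.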